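A few compounds are considered here, and "the series" means these few. Any claim that something is new, unique, unknown or untested is made for them only; others in the source may bear on it.

Compound 1 `Nc1cc(N)c2nc(-c3ccccc3)c(Oc3ccc(Cl)c(Cl)c3)nc2c1` carries a 3,4-dichlorophenoxy group on its core. In a functional assay on SN12C cells (Homo sapiens) for inhibition, read by sulforhodamine B assay, with a stated time of 48 h (on this read-out higher numbers stand for weaker inhibition of growth and lower numbers for stronger inhibition of growth), compound 1 gives only a limit, < 100000 nM, and not a number. Where it stands among the measured values is therefore known only through (the limit of < 100000 nM in this assay, at which 1 of the 2 values shown sits). A related compound 2 `COc1cc(CNc2nc3cc(N)cc(N)c3nc2-c2ccccc2)cc(OC)c1OC` gives 16600 nM in this assay. Compound 3 `Nc1cc(N)c2nc(-c3ccccc3)c(Sc3ccc(Cl)c(Cl)c3)nc2c1` is compound 1 with a single change: (3,4-dichlorophenyl)sulfanyl in place of 3,4-dichlorophenoxy on an aromatic carbon. No measured pair here isolates such a swap, so the size of this step cannot be read from the numbers shown, and the expectation is a change no larger than the usual scatter, with no set direction. On that basis compound 3 is expected to give about 35000 nM, with a likely range from 8000 nM to 100000 nM. This implies an expected step that the limit leaves unreadable from compound 1 to compound 3 in this assay.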

Compound 3, concentration for total growth inhibition: 23400 nM
Compound 3: middle estimate off by 1.5-fold (0.17 log units), on the high side, within the range that was stated.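

Within the data shown here, no step from compound 1 to compound 3 can be read, because compound 1 gives only a limit and not a number in this assay: the limit of < 100000 nM in this assay, at which 1 of the 3 values shown sits. Going by these compounds, whether (3,4-dichlorophenyl)sulfanyl in place of 3,4-dichlorophenoxy changes growth inhibition, and in which direction, stays open.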